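A few compounds are considered here, and "the series" means these few. Any claim that something is new, unique, unknown or untested is made for them only; others in the source may bear on it.

Compound 1 `O=C(O)COc1ccc(NC(=O)COc2ccccc2)cc1F` gives 29.8% in a functional assay on CHO cells for agonist activity at Free fatty acid receptor 1 (Homo sapiens), read by FLIPR, tested at 100 nM; a lower number here means a weaker effect, a higher number a stronger effect of the compound at the concentration tested. Compound 2 `CC(Oc1ccccc1)C(=O)Nc1ccc(OCC(=O)O)c(F)c1` gives 35.7% in this assay, and compound 3 `CC(Oc1cccc(C(C)(C)C)c1)C(=O)Nc1ccc(OCC(=O)O)c(F)c1` gives 32.8% in this assay. Compound 2 holds the highest of the three numbers, with compound 3 nearest and compound 1 furthest, both gaps within the scatter. The two measured steps are a number 5.9 percentage points higher from compound 1 to compound 2 (within the scatter) and a number 2.9 percentage points lower from compound 2 to compound 3 (within the scatter), neither beyond the scatter. Compound 4 `Cc1ccc(OC(C)C(=O)Nc2ccc(OCC(=O)O)c(F)c2)cc1C` is not yet measured; it differs from compound 2 by 3,4-dimethylphenyl in place of phenyl on an oxygen on a saturated carbon. The step that bears on it most is the one adding tert-butyl on an aromatic carbon, a number 2.9 percentage points lower from compound 2 to compound 3 (within the scatter), which stayed within the scatter. Accordingly no step beyond the scatter is expected in this assay, the expected step being a number 1.7 percentage points lower from compound 2 to compound 4 (within the scatter). Compound 4 is therefore estimated at 34%, within 22% to 46%.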

Compound 4, a percentage reported as activity, at one concentration (the size of the read-out at that concentration, not a potency): 36.8%
The estimate for compound 4 lay 2.8 percentage points below the measured number; the range from low to high includes it.
By their numbers in this assay, from the lowest: compounds 1, 3, 2 and 4 (each within the scatter of the next).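

Placing 3,4-dimethylphenyl on the oxygen gives a number 1.1 percentage points higher from compound 2 to compound 4 (within the scatter) in this assay. Going by these compounds alone, two methyl groups on this aromatic ring therefore leave the read-out within the scatter, as does the single tert-butyl in a number 2.9 percentage points lower from compound 2 to compound 3 (within the scatter), so neither substitution yet shows any effect at this position. No measurement at hand offers an explanation for this flat result. Still open, from the compounds shown here alone, is whether an amine or a carboxylic acid on this aromatic ring would produce a step beyond the scatter. Going by these compounds, a longer chain in place of the methyl on the saturated chain carbon also remains untested in these compounds.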